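Ethoxy to Chloro: What the Distribution Volume Might Do

This account rests on a few compounds, and the source may have more. Where it says the series, first, only, none or still open, it means among the compounds named here.

Compound 1 `CCOc1cc2oc(=O)n(CCC(=O)O)c2cc1Cl` carries an ethoxy group on its aromatic core, and in an ADME assay on the whole organism (strain Han-Wistar) for pharmacokinetics, with Rattus norvegicus as the target, read by LC-MS, at a dose of 1 mg/kg by the intravenous route (a lower number here means that more of the compound stays in the plasma, a higher number that more of the compound sits outside the plasma), compound 1 gives 0.36 L/kg. Going by the values given here, of the two numbers measured so far this is the lower one. The other measured compound, compound 2 `C[C@@H](Oc1cc2onc(CCC(=O)O)c2cc1Cl)c1ccccn1`, gives 0.42 L/kg in this assay; the gap between the two lies within the scatter of repeated measurements, so the two values show no difference that can be read as an order. Compound 3 `O=C(O)CCn1c(=O)oc2cc(Cl)c(Cl)cc21` has not yet been measured in this assay. It differs from compound 1 in one place: chloro in place of ethoxy on an aromatic carbon. The rest of the structure is shared between the two compounds, so the one substituent is the whole of the change. Among the compounds with values here, no measured pair of this kind exists to lean on, and the change is small in size, so no step beyond the scatter is expected: the estimated step of a 1.1-fold higher number from compound 1 to compound 3 (0.05 log units; within the scatter) is meant to leave the number about where compound 1 stands. Compound 3 is therefore expected to give 0.4 L/kg in this assay, with a range from 0.25 L/kg to 0.65 L/kg.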

Compound 3, volume of distribution at steady state in the Rattus norvegicus assay: 0.28 L/kg
Beside the measured number, compound 3's estimate is 1.4-fold (0.15 log units) above it, and the stated range covers the measured number.
By their numbers in the Rattus norvegicus assay, from the lowest: compounds 3, 1 and 2 (each within the scatter of the next).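

Chloro in place of ethoxy on this aromatic carbon gives the first measured step of its kind, and in the Rattus norvegicus assay it is a 1.3-fold lower number from compound 1 to compound 3 (0.11 log units; within the scatter), so this read-out does not separate the two compounds. In a physicochemical assay for solubility, with a stated time of 24 h (on this read-out lower numbers stand for lower solubility and higher numbers for higher solubility), compound 1 gives > 1880 ug/mL, which is a limit of the assay and not a number. In the physicochemical assay compound 3 gives 270 ug/mL. In the physicochemical assay the step is an at least 6.9-fold lower number from compound 1 to compound 3 (0.84 log units; beyond the scatter), so the same single change that stays within the scatter for volume of distribution goes beyond it for solubility. The size of this step is only a bound set by the limit of compound 1: the limit of > 1880 ug/mL in the physicochemical assay, at which 1 of the 2 values shown sits.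

The compounds shown leave open how far the solubility step really reaches, and whether another group on the same aromatic carbon, such as methoxy, a longer alkoxy chain or an amine, would fall closer to ethoxy or to chloro in either read-out. They also leave open whether this one exchange would act the same way on a different core, since a single pair of compounds sets no pattern.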